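The compounds below may be only part of what the source reports. "The series", "measured", "known", "first", "only" and "open" are said of these compounds alone.

Working notes on the series.

Compound 1 `O[C@@H]1Cc2cc(Cl)ccc2N[C@H](c2ccc(Cl)cc2)C1` sits in an ADME assay on Vero cells (Chlorocebus sabaeus) for cytotoxicity, read by MTT assay, with a stated time of 72 h (a higher number here means that more compound is tolerated, a lower number that less compound is tolerated), at 76600 nM. Compound 2 `O[C@@H]1Cc2cc(F)ccc2N[C@H](c2ccc(Cl)cc2)C1` is the fluoro partner: in this assay compound 2 gives 194000 nM. The step of a 2.5-fold higher number from compound 1 to compound 2 (0.40 log units; beyond the scatter) is the change (fluoro in place of chloro on an aromatic carbon).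

Compound 3 `O[C@@H]1Cc2ccccc2N[C@H](c2ccccc2Cl)C1` gives in this assay > 300000 nM, which is a limit of the assay and not a number. The evidence here is the limit of > 300000 nM in this assay, at which 1 of the 3 values shown sits.

Compound 4 `O[C@@H]1Cc2ccccc2N[C@H](c2ccccc2F)C1` has not been measured in this assay. From compound 3 it differs by fluoro in place of chloro on an aromatic carbon. This is the same kind of change as from compound 1 to compound 2, but the surroundings differ: in the measured pair the fluoro sits on a ring that is part of a fused or bridged system of two rings, meta to a fused ring and para to a fused ring, whereas in compound 4 it sits on a six-membered aromatic ring of carbon only, ortho to a large group. How the core of compound 3 differs from the core of compound 1 is not broken down here.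

For compound 4 a step that the limit leaves unreadable from compound 3 to compound 4 is expected, resting on compound 1 and compound 2 because a 2.5-fold higher number from compound 1 to compound 2 (0.40 log units; beyond the scatter) went toward more tolerated compound, and compound 3 already stands at the limit of > 300000 nM in this assay, at which 1 of the 3 values shown sits. Compound 4 is therefore estimated at 500000 nM, with a range from 250000 nM to 1500000 nM, and a value reported only as a limit is expected as the most likely outcome.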

Compound 4, half-maximal cytotoxic concentration: > 300000 nM
Compound 4: no number, only a limit (the forecaster's own chance of this, stated with the estimate: 80%); the middle value is on the limit's open side.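

In this assay compound 4 gives > 300000 nM, which is a limit of the assay and not a number. Compound 3 also stands at a limit, so no step between compound 3 and compound 4 can be read: the limit of > 300000 nM in this assay, at which 2 of the 4 values shown sit.

The compounds shown leave open whether fluoro in place of chloro, ortho to a large group, shifts the number at all.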